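Swapping Methoxy for Dimethylamino on a Long Chain

This account rests on a few compounds, and the source may have more. Where it says the series, first, only, none or still open, it means among the compounds named here.

Values so far in a functional assay on SW480 cells (Homo sapiens) for antiproliferative activity, read by MTT assay, with a stated time of 48 h (a higher number here means a weaker inhibitor, a lower number a stronger inhibitor), are these:
- compound 1 `CCCCCC(CCO)n1cnc2c(N(C)C)ncnc21`: > 50000 nM as a limit
- compound 2 `CCCCCCCCC(CCO)n1cnc2c(N(C)C)ncnc21`: 21600 nM as a number
- compound 3 `CCCCCCCCCC(CCO)n1cnc2c(OC)ncnc21`: 3250 nM as a number

Compound 3 holds the lowest number at 3250 nM and compound 2 lies beyond the scatter above it. Compound 4 `CCCCCCCCCC(CCO)n1cnc2c(N(C)C)ncnc21` keeps the chain of compound 3 and makes one change dimethylamino in place of methoxy on an aromatic carbon with dimethylamino in place of methoxy on an aromatic carbon. Going by the values given here, no measured step isolates this exchange. Among the compounds with values here, the one measured step of an at least 2.3-fold lower number from compound 1 to compound 2 (0.36 log units; beyond the scatter) lengthens the chain while dimethylamino stays. Compound 2 carries dimethylamino on a shorter chain at 21600 nM so a moderate rise is expected, and the longer chain should hold it below that value. The expected step is a 2.8-fold higher number from compound 3 to compound 4 (0.44 log units; beyond the scatter) in this assay on this estimate. For compound 4 the estimated value is 9000 nM with an expected range from 2500 nM to 30000 nM in this assay when measured.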

Compound 4, half-maximal inhibitory concentration: 12200 nM
Estimate against measurement, compound 4: 1.4-fold (0.13 log units) below, and the stated range covers the measured number.
By their numbers in this assay, from the lowest: compound 3; then compounds 4 and 2 (each within the scatter of the next). At a limit, above all of these: compound 1.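

The exchange of methoxy for dimethylamino on this aromatic carbon, now read on a single chain, gives a 3.8-fold higher number from compound 3 to compound 4 (0.57 log units; beyond the scatter) in this assay and so separates the effect of this group from that of the chain. With dimethylamino kept, one added methyl gives a 1.8-fold lower number from compound 2 to compound 4 (0.25 log units; within the scatter) and an added butyl gives an at least 4.0-fold lower number from compound 1 to compound 4 (0.61 log units; beyond the scatter) on the same chain carbon series. Compound 1 stands at a limit, so that last step is only a bound: the limit of > 50000 nM in this assay, at which 1 of the 4 values shown sits.

On these data alone, whether an amine such as methylamino or a group such as ethoxy on this carbon would fall nearer methoxy or dimethylamino remains open. So does whether a longer chain would lower the number further with methoxy in place.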